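This account rests on a few compounds, and the source may have more. Where it says the series, first, only, none or still open, it means among the compounds named here.

Working notes on the series: compound 1 (`CN(C)C(=O)c1cc2cnc(Nc3ccc(NC(=O)C4(C(=O)Nc5ccc(Cl)cc5)CC4)cc3)nc2n1C1CCCC1`), compound 2 (`CN(C)C(=O)c1cc2cnc(Nc3ccc(NC(=O)C4(C(=O)Nc5cccc(O)c5)CC4)cc3)nc2n1C1CCCC1`), compound 3 (`CN(C)C(=O)c1cc2cnc(Nc3ccc(NC(=O)C4(C(=O)Nc5ccc(Cl)c(C(F)(F)F)c5)CC4)cc3)nc2n1C1CCCC1`) and the unmeasured compound 4 (`CN(C)C(=O)c1cc2cnc(Nc3ccc(NC(=O)C4(C(=O)Nc5cccc(Br)c5)CC4)cc3)nc2n1C1CCCC1`) share one core and differ in the aryl group on an amide-type nitrogen. In a functional assay on OVCAR-5 cells (Homo sapiens) for inhibition, read by CCK-8 assay, with a stated time of 72 h, tested at 1 uM (a lower number here means less inhibition of growth, a higher number more inhibition of growth at the concentration tested), compound 1 gives 8.1%, compound 2 gives 58.5% and compound 3 gives -2.4%. Compound 3 therefore stands lowest of the three.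

The change now in view is 3-bromophenyl in place of 4-chloro-3-(trifluoromethyl)phenyl on an amide-type nitrogen.

Within the data shown here, three measured steps bear on it. Trifluoromethyl in place of hydrogen on an aromatic carbon gave a number 10.5 percentage points lower from compound 1 to compound 3 (beyond the scatter), a modest step. 3-Hydroxyphenyl in place of 4-chlorophenyl gave a number 50.4 percentage points higher from compound 1 to compound 2 (beyond the scatter), and 4-chloro-3-(trifluoromethyl)phenyl in place of 3-hydroxyphenyl gave a number 60.9 percentage points lower from compound 2 to compound 3 (beyond the scatter), both large. Among the measured compounds shown here, the high value so far belongs to compound 2 alone, at 58.5%, and compound 4 carries no hydroxy group. For the measured compounds named here, no measured compound has a bromine, so the size of the step is poorly fixed.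

A modest rise is expected, with an estimated a number 17.4 percentage points higher from compound 3 to compound 4 (beyond the scatter). The expected value for compound 4 is 15%, within an estimated range of -3% to 42%.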

Compound 4, percent growth inhibition at one concentration: 0.04%
Compound 4: the middle estimate sits 15 percentage points above what was measured; measured number inside the range.
By their numbers in this assay, from the lowest: compounds 3, 4 and 1 (each within the scatter of the next, the first and the last beyond it); then compound 2.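

In this assay, bromo in place of hydroxy on an aromatic carbon gives a number 58.5 percentage points lower from compound 2 to compound 4 (beyond the scatter), the first comparison in the series in which that single substituent alone changes, and it ties the high number of compound 2 to the hydroxy group rather than to a substituent at that place on the ring in general. 3-Bromophenyl in place of 4-chloro-3-(trifluoromethyl)phenyl gives a number 2.4 percentage points higher from compound 3 to compound 4 (within the scatter), and 3-bromophenyl in place of 4-chlorophenyl gives a number 8.1 percentage points lower from compound 1 to compound 4 (within the scatter), so within this assay neither step separates the bromine compound from the two chlorine-bearing compounds, and among these four compounds only the one with a hydroxy group stands high, with none going against this. Nothing available here explains why the hydroxy compound stands apart.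

Open, going by these compounds, is whether the high number needs the hydroxy group itself, or whether an amine, a carboxylic acid or a methoxy group on the same aromatic carbon would also hold it. Also open, on these data alone, is whether a hydroxy group on the 4-chlorophenyl ring would raise the number of compound 1 in this assay.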